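Swapping a fluorobenzyl for cyclohexyl on the triazole

The compounds below may be only part of what the source reports. "The series", "measured", "known", "first", "only" and "open" are said of these compounds alone.

Of the compounds shown here, two of a shared core have been tested in a functional assay on RAW264.7 cells (Mus musculus) for inhibition, read by Griess assay, with stated times of 2 h and 24 h; on this read-out higher numbers stand for weaker inhibition and lower numbers for stronger inhibition. Compound 1 `CCn1cc(COc2cc(O)c3c(c2)O[C@H](c2ccc(OC)c(O)c2)C/C3=N\O)nn1` gives 3140 nM in this assay. Compound 2 `COc1ccc([C@@H]2CC(=O)c3c(O)cc(OCc4cn(Cc5ccccc5F)nn4)cc3O2)cc1O` gives 7320 nM in this assay, the higher of the two numbers; compound 1 stands a clear step lower, beyond the scatter. Among the compounds with values here, no pair differing in one place has been measured, so no single change has a known size here.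

Compound 3 `COc1ccc([C@@H]2CC(=O)c3c(O)cc(OCc4cn(C5CCCCC5)nn4)cc3O2)cc1O` differs from compound 2 in one place: cyclohexyl in place of 2-fluorobenzyl on an aromatic nitrogen.

Within the data shown here, with no comparable step to lean on, the change is expected to move this assay only a little, and the step of a 1.2-fold lower number from compound 2 to compound 3 (0.09 log units; within the scatter) is estimated to stay within the scatter, in either direction. Compound 3 is therefore expected to give about 6000 nM in this assay, between 2500 nM and 14000 nM.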

Compound 3, half-maximal inhibitory concentration: 15600 nM
Estimate against measurement, compound 3: 2.6-fold (0.41 log units) below; the whole stated range lies below it.
By their numbers in this assay, from the lowest: compound 1; then compound 2; then compound 3.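

Swapping 2-fluorobenzyl for cyclohexyl on the aromatic nitrogen gives the first single change of known size in this set: in this assay, the step is a 2.1-fold higher number from compound 2 to compound 3 (0.33 log units; beyond the scatter). The position is therefore not indifferent to the group it carries, and of these two groups 2-fluorobenzyl goes with the stronger inhibition, although the step is modest. Nothing available accounts for this difference.

The change replaces the whole group, so the contribution of the fluorine cannot be separated from that of the aromatic ring, and an unsubstituted benzyl on the same nitrogen would address that question. From the compounds shown here alone, it also remains open how a carboxylic acid or an amine on a longer chain would fare there, and whether the step carries over to the core of compound 1.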